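Formyl gives way to 2-carboxyethenyl at the limit

The source may report more compounds than this note shows. Statements on the series, on what has been measured and on what is new or still open speak of the compounds shown alone.

Measured in a functional assay on HepG2 cells (Homo sapiens) for cytotoxicity, with a stated time of 72 h; a lower number here means that less compound is needed, a higher number that more compound is needed for the effect:
Compound 1 `C=C[C@@](C)(/C=C/c1ccc(O)cc1)CCC1OC1(C)C`: > 52000 nM (a limit)
Compound 2 `C=C[C@@](C)(/C=C/c1ccc(O)cc1)CC/C=C/C#N`: > 52000 nM (a limit)
Compound 3 `C=C[C@@](C)(/C=C/c1ccc(O)c(C=O)c1)CCC=C(C)C`: > 52000 nM (a limit)

Compound 3 has no number of its own: compound 3 gives > 52000 nM, which is a limit of the assay and not a measured value. Among the measured compounds shown here, all the compounds tested so far stand at the limit of > 52000 nM in this assay, at which 3 of the 3 values shown sit.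

Compound 4 `C=C[C@@](C)(/C=C/c1ccc(O)c(/C=C/C(=O)O)c1)CCC=C(C)C` keeps the core of compound 3 and differs in one place: 2-carboxyethenyl in place of formyl on an aromatic carbon. The 2-carboxyethenyl stands in place of the formyl on an aromatic carbon, ortho to a hydroxy group.

For the measured compounds named here, only one measured step exists to compare with, and it offers little guidance. That step, a step that the two limits leave unreadable from compound 1 to compound 2, concerns the chain and not the aromatic carbon, and it has no readable size. Going by the values given here, no measured step therefore shows a change in either direction.

Among the compounds with values here, with compound 3 at the limit of > 52000 nM, no step of readable size is expected in this assay, and compound 4 will most likely report only a limit too. The expected step, a step that the limit leaves unreadable from compound 3 to compound 4, is an estimate with no measured size behind it. For compound 4 the estimated value is 60000 nM, with an expected range of 30000 nM to 120000 nM.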

Compound 4, half-maximal effective concentration: > 52000 nM
Compound 4: no number, only a limit (the forecaster's own chance of this, stated with the estimate: 80%); the middle value is on the limit's open side.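

In this assay compound 4 gives > 52000 nM, which is a limit of the assay and not a number. Compound 3 also stands at a limit, so no step can be read between compound 3 and compound 4. The compounds shown leave open whether any of these changes alters the half-maximal effective concentration, and they share one result: the limit of > 52000 nM in this assay, at which 4 of the 4 values shown sit.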